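This account rests on a few compounds, and the source may have more. Where it says the series, first, only, none or still open, it means among the compounds named here.

In a functional assay on NCI-H522 cells (Homo sapiens) for cytotoxicity, read by sulforhodamine B assay, with a stated time of 48 h (a higher number here means a weaker inhibitor of growth, a lower number a stronger inhibitor of growth), the three measured compounds stand as follows:

Compound 1 `ClCc1ccccc1Cn1cnc2c(Cl)nc(Cl)nc21`: 580 nM
Compound 2 `ClCc1ccccc1Cn1cnc2c(Cl)ncnc21`: 1820 nM
Compound 3 `ClCc1cccc(Cn2cnc3c(Cl)ncnc32)c1`: 18600 nM

Compound 1 and compound 2 share a core, and compound 1 differs from compound 2 by chloro in place of hydrogen on an aromatic carbon; this gives the step of a 3.1-fold lower number from compound 2 to compound 1 (0.50 log units; beyond the scatter). Compound 3 has the same atoms as compound 2 joined differently, and the difference between the two cores is not broken down here. Compound 3 shows the highest number of the three. Compound 4 `ClCc1cccc(Cn2cnc3c(Cl)nc(Cl)nc32)c1` has not yet been measured; it differs from compound 3 by chloro in place of hydrogen on an aromatic carbon, the same change as that from compound 2 to compound 1. In this assay compound 4 is expected to show a step of a 3.1-fold lower number from compound 3 to compound 4 (0.49 log units; beyond the scatter). Within the data shown here, this expectation rests on the single earlier step of a 3.1-fold lower number from compound 2 to compound 1 (0.50 log units; beyond the scatter) seen for this change. The estimate for compound 4 is 6000 nM, most likely between 2500 nM and 15000 nM.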

Compound 4, concentration for 50% growth inhibition: 2690 nM
For compound 4 the middle estimate is 2.2-fold (0.35 log units) above the measured one; the range from low to high includes it.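

In this assay, chloro in place of hydrogen on an aromatic carbon gives a 6.9-fold lower number from compound 3 to compound 4 (0.84 log units; beyond the scatter), the same direction as on the other core. The two steps agree in size as far as these data can tell: the same change on two cores in this assay, a 3.1-fold lower number (0.50 log units; beyond the scatter) from compound 2 to compound 1 and a 6.9-fold lower number (0.84 log units; beyond the scatter) from compound 3 to compound 4, 2.2-fold (0.34 log units) apart, within the scatter of two such steps. So the change carries across these two closely related cores, but a single pair of steps shows neither that it would carry to a core of another kind nor why the number falls.

The compounds shown leave open whether another group on that carbon, such as an amine or a methoxy group, would do what chloro does. They also leave open what happens when a methyl or hydroxymethyl group stands in place of the chloromethyl group.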